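From cyclohexyl to isopropyl at the assay limit

This account rests on a few compounds, and the source may have more. Where it says the series, first, only, none or still open, it means among the compounds named here.

- compound 1 `O=C1COc2ccc(-c3cnc(Cl)c(NS(=O)(=O)c4ccc(F)cc4)c3)cc2N1C1CCCCC1` gives > 40000 nM as a limit
- compound 2 `COc1ncc(-c2ccc3c(c2)N(C2CCCCC2)C(=O)CO3)cc1NS(=O)(=O)c1ccc(F)cc1` gives > 40000 nM as a limit

Both entries come from a functional assay on A-375 cells (Homo sapiens) for antiproliferative activity, read by MTT assay, with a stated time of 72 h (on this read-out lower numbers stand for stronger inhibition and higher numbers for weaker inhibition), and neither is a number. Compound 1 therefore stands only at a limit, and the whole set so far is summed up by the limit of > 40000 nM in this assay, at which 2 of the 2 values shown sit, with no potency yet readable.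

Compound 3 `CC(C)N1C(=O)COc2ccc(-c3cnc(Cl)c(NS(=O)(=O)c4ccc(F)cc4)c3)cc21` differs from compound 1 in one place, with isopropyl in place of cyclohexyl on an amide-type nitrogen in a ring, as counted in isopropyl in place of cyclohexyl on an amide-type nitrogen in a ring while the rest of the structure is shared.

Within the data shown here, the only measured step is a step that the two limits leave unreadable from compound 1 to compound 2 and it concerns methoxy in place of chloro, a different change, so it offers no size to carry over. Among the measured compounds shown here, no measured step touches the cyclohexyl group. In this assay no step beyond the scatter is therefore expected, though the limit hides how far compound 1 really lies.

The estimated step is a number no higher from compound 1 to compound 3 (the limit leaves the size open) and it should be read as an expectation only. Compound 3 is expected to give 40000 nM with an estimated range from 12000 nM to 80000 nM and a report as a limit is the likeliest outcome.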

Compound 3, half-maximal inhibitory concentration: 25500 nM
The estimate for compound 3 lay 1.6-fold (0.20 log units) above the measured number, and the stated range covers the measured number.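

In this assay, among these compounds, the amide-type nitrogen of the ring is the first place in this set where a change yields a number instead of a limit: compound 3, which carries isopropyl in place of cyclohexyl, gives 25500 nM. The change reads as an at least 1.5-fold lower number from compound 1 to compound 3 (0.19 log units; that floor lies within the scatter), and because that figure is only a floor, it does not by itself establish a real gain, while the true size stays hidden behind the limit of compound 1. Among the compounds shown here, the step from methoxy in place of chloro cannot be read, so this is the only step with any size, and the set as a whole still rests largely on a limit: the limit of > 40000 nM in this assay, at which 2 of the 3 values shown sit.

The compounds shown leave open where the number would fall with methyl on the same nitrogen, or with a longer chain ending in an amine or a carboxylic acid. They also leave open whether methoxy in place of chloro would give a readable step if it were set on the isopropyl compound.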